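This account rests on a few compounds, and the source may have more. Where it says the series, first, only, none or still open, it means among the compounds named here.

Among the compounds with values here, compound 2 `COc1cc(-c2nn(-c3ccc(NC(=O)Nc4cc(C(F)(F)F)cc(C(F)(F)F)c4)cc3)cc2-c2ccncc2)ccc1Cl` is one of three compounds measured in a functional assay on SK-MEL-28 cells (Homo sapiens) for antiproliferative activity, read by sulforhodamine B assay, with a stated time of 48 h; a higher number here means a weaker inhibitor, a lower number a stronger inhibitor. In this assay compound 2 gives 1930 nM, the second highest of the three numbers. Compound 1 `COc1cc(-c2nn(-c3ccc(NC(=O)Nc4ccc(Cl)c(C(F)(F)F)c4)cc3)cc2-c2ccncc2)ccc1Cl` gives 1880 nM, which lies within the scatter of compound 2, so no order between these two can be read. Compound 3 `COc1cc(-c2nn(-c3ccc(NC(=O)c4ccc(Cl)c(Cl)c4)cc3)cc2-c2ccncc2)ccc1Cl` gives 40300 nM, far beyond the scatter from compound 2. Within the data shown here, the one step between measured compounds that differ in a single place, a 21-fold higher number from compound 1 to compound 3 (1.33 log units; beyond the scatter), concerns the group on the carbonyl carbon, not the part changed here. Compound 4 `O=C(Nc1ccc(-n2cc(-c3ccncc3)c(-c3ccc(Cl)c(O)c3)n2)cc1)Nc1cc(C(F)(F)F)cc(C(F)(F)F)c1` differs from compound 2 by hydrogen in place of methyl on an oxygen on an aromatic ring, that is methoxy to hydroxy, 4-chloro-3-methoxyphenyl to 4-chloro-3-hydroxyphenyl. Among the measured compounds shown here, no measured step bears on this change, so the data give no direction for it, and a step within the scatter is the expectation; the expected step is a 1.0-fold higher number from compound 2 to compound 4 (0.02 log units; within the scatter). Compound 4 is therefore expected to give about 2000 nM in this assay, in a range from 700 nM to 6000 nM.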

Compound 4, half-maximal inhibitory concentration: 2010 nM
Estimate against measurement, compound 4: 1.0-fold (0.00 log units) below, and the stated range covers the measured number.
By their numbers in this assay, from the lowest: compounds 1, 2 and 4 (each within the scatter of the next); then compound 3.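

Going from methoxy to hydroxy on the aromatic ring gives a 1.0-fold higher number from compound 2 to compound 4 (0.02 log units; within the scatter) in this assay, so the two numbers cannot be told apart and the methyl on this oxygen is not needed to keep the value of compound 2. Within the data shown here, compounds 1, 2 and 3 all carry the methoxy and so said nothing about this position, while the one large step among them, a 21-fold higher number from compound 1 to compound 3 (1.33 log units; beyond the scatter), concerns the group on the carbonyl carbon. No measured evidence accounts for this result.

The compounds shown leave open whether an amine, a carboxylic acid or a longer chain such as ethoxy on this aromatic ring would also stay within the scatter of compound 2. On these data alone, it also remains open whether methoxy to hydroxy would read the same way in compound 1 or compound 3.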